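Aryl Ketone Replaces Ethyl Ketone on Compound 3

The compounds below may be only part of what the source reports. "The series", "measured", "known", "first", "only" and "open" are said of these compounds alone.

Compound 3 `CCC(=O)c1sc2nc(-c3cccs3)ccc2c1N` is one of a small set of compounds sharing a core and tested in a functional assay on WI-38 VA13 cells (Homo sapiens) for cytotoxicity; a lower number here means that less compound is needed, a higher number that more compound is needed for the effect. In this assay compound 3 gives 0.89 ug/mL, the highest of the two numbers in the set. Compound 1 `CNc1c(C(=O)c2ccccc2)sc2nc(-c3cccs3)ccc12` gives 0.42 ug/mL in this assay. Compound 2 `CN(C)c1c(C(=O)c2ccccc2)sc2nc(-c3cccs3)ccc12` reaches only a limit of this assay, > 4 ug/mL. Among the compounds with values here, the one step that can be read directly is an at least 9.5-fold higher number from compound 1 to compound 2 (0.97 log units; beyond the scatter), which concerns a nitrogen on an aromatic ring and not the ketone side chain, so it does not bear on the change considered here.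

Compound 4 `Nc1c(C(=O)c2ccc(F)cc2F)sc2nc(-c3cccs3)ccc12` differs from compound 3 by 2,4-difluorophenyl in place of ethyl on a carbonyl carbon. Compound 1 also carries an aromatic ring on that carbonyl carbon, but it differs from compound 3 at the nitrogen as well, so its two values alone give the only hint. On that basis compound 4 is expected to show a step of a 1.8-fold lower number from compound 3 to compound 4 (0.25 log units; within the scatter) in this assay, giving an estimate of 0.5 ug/mL, within a range from 0.2 ug/mL to 1.5 ug/mL.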

Compound 4, half-maximal effective concentration: 2.3 ug/mL
Estimate against measurement, compound 4: 4.6-fold (0.66 log units) below, outside the stated range (above it).
By their numbers in this assay, from the lowest: compound 1; then compound 3; then compound 4. At a limit, above all of these: compound 2.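

At this position, on a carbonyl carbon, the exchange of ethyl for 2,4-difluorophenyl can now be read directly in this assay (a 2.6-fold higher number from compound 3 to compound 4 (0.41 log units; beyond the scatter)), so more compound is needed for the effect once this ring is in place. Compound 1 could not show this, as it differs from compound 3 at the nitrogen as well, whereas compounds 3 and 4 differ only in this one group. Compound 4 still gives a measured number, and the only compound in the set that stands at a limit of the assay, rather than at a number, is compound 2: the limit of > 4 ug/mL in this assay, at which 1 of the 4 values shown sits.

From the compounds shown here alone, the ring and its two fluorines cannot be separated here, so what a plain phenyl would do on the same carbonyl carbon of this amine stays open. Also open, going by these compounds, is how a longer chain, such as butyl, or a small ring, such as cyclopropyl, would compare with ethyl.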